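The compounds below may be only part of what the source reports. "The series", "measured", "known", "first", "only" and "open" are said of these compounds alone.

Of the compounds shown here, three of one shared core have been tested in an ADME assay on HFF cells (Homo sapiens) for cytotoxicity, read by MTT assay, with a stated time of 72 h; a lower number here means a stronger inhibitor, a higher number a weaker inhibitor. Compound 1 `CCCCc1cn(C[C@H](O)[C@H]2OC(=O)C(OCc3ccccc3)=C2OCc2ccccc2)nn1` gives 26300 nM. Compound 2 `O=C1O[C@H]([C@@H](O)Cn2cc(CNS(=O)(=O)c3ccc(F)cc3)nn2)C(OCc2ccccc2)=C1OCc1ccccc1` gives 30 nM. Compound 3 `O=C1O[C@H]([C@@H](O)Cn2cc(C3CC3)nn2)C(OCc2ccccc2)=C1OCc1ccccc1` gives 24300 nM. Among these three numbers, compound 3 stands second highest; its nearest neighbour is compound 1, and its furthest is compound 2. The step of a 1.1-fold lower number from compound 1 to compound 3 (0.03 log units; within the scatter) shows that exchanging one small hydrocarbon group for another at the same position on the five-membered ring left the number where it was, whereas the step of an 880-fold lower number from compound 1 to compound 2 (2.94 log units; beyond the scatter) and the step of an 810-fold higher number from compound 2 to compound 3 (2.91 log units; beyond the scatter) show that the sulfonamide-bearing group sets compound 2 far apart from both others.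

Compound 4 `Cc1ccc(-c2cn(C[C@H](O)[C@H]3OC(=O)C(OCc4ccccc4)=C3OCc3ccccc3)nn2)cc1` is not yet measured. It differs from compound 3 in one place: 4-methylphenyl in place of cyclopropyl on an aromatic carbon. The group that enters is again built of carbon only, with no hydrogen-bond donors or acceptors, just as the cyclopropyl it replaces. Among the measured compounds shown here, the step that bears most directly on this change is the one from compound 1 to compound 3, which stayed within the scatter, while the large steps both involve the sulfonamide and not a hydrocarbon group. The expected step of a 1.6-fold lower number from compound 3 to compound 4 (0.21 log units; within the scatter) is therefore small. Compound 4 is estimated at 15000 nM, within a range from 4000 nM to 45000 nM.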

Compound 4, half-maximal inhibitory concentration: > 100000 nM
Compound 4 ended at the assay's limit (the forecaster's own chance of this, stated with the estimate: 10%); at least 6.6-fold (0.82 log units) between middle value and limit.
By their numbers in this assay, from the lowest: compound 2; then compounds 3 and 1 (each within the scatter of the next). At a limit, above all of these: compound 4.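

In this assay, the result for compound 4 is a limit of the assay and not a number, printed as > 100000 nM, and it is not the only thing to keep in view: the limit of > 100000 nM in this assay, at which 1 of the 4 values shown sits.

Even as a limit, it shows that this position on the five-membered aromatic ring does not treat all carbon-only groups alike, as the step of an at least 4.1-fold higher number from compound 3 to compound 4 (0.61 log units; beyond the scatter) and the step of an at least 3.8-fold higher number from compound 1 to compound 4 (0.58 log units; beyond the scatter) both lie beyond the scatter, whereas the earlier exchange of butyl for cyclopropyl stayed within it. The step of an at least 3300-fold higher number from compound 2 to compound 4 (3.52 log units; beyond the scatter) also widens the span of numbers seen at this one position, with the (((4-fluorophenyl)sulfonyl)amino)methyl group of compound 2 at the low end and the 4-methylphenyl group of compound 4 at the high end.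

On these data alone, how far past its limit compound 4 lies remains open, and with it the true size of these steps. Also open, as far as these compounds go, is whether the change follows the aromatic ring or the methyl on it: a plain phenyl at this position would separate the two, and a phenyl carrying an amine or a carboxylic acid would extend the comparison.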